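Glucagon receptor series: aryl swap on the ring nitrogen

The source may hold more compounds than are shown below. What is called first, only, known or untested is meant among the compounds shown, and "the series" means these compounds.

Measured so far:
compound 1 `O=C(O)CCNC(=O)c1ccc(CN(c2ccc3c(c2)CCC3)c2nc(-c3ccc(C(F)(F)F)cc3)cs2)cc1` gives 64 nM in an in vitro assay on BHK cells for binding affinity to Glucagon receptor (Homo sapiens); on this read-out lower numbers stand for stronger inhibition and higher numbers for weaker inhibition
compound 2 `O=C(O)CCNC(=O)c1ccc(CN(c2ccc3c(c2)CCCC3)c2nc(-c3ccc(Cl)c(Cl)c3)cs2)cc1` gives 54 nM in this assay
compound 3 `O=C(O)CCNC(=O)c1ccc(CC(c2ccc(Cl)cc2)c2nc(-c3ccc(OC(F)(F)F)cc3)cs2)cc1` gives 25 nM in this assay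

Compound 1 shows the highest number of the three. Compound 2 lies within the scatter of it, so no order between them is claimed; compound 3 sits beyond the scatter, with the lower number.

Compound 4 `O=C(O)CCNC(=O)c1ccc(CN(c2ccc(OC(F)(F)F)cc2)c2nc(-c3ccc(C(F)(F)F)cc3)cs2)cc1` is not yet measured. Relative to compound 1 it carries 4-(trifluoromethoxy)phenyl in place of 2,3-dihydro-1H-inden-5-yl on a nitrogen on an aromatic ring. Going by the values given here, no pair among the measured compounds differs by one change, so this swap has no direct precedent here; the nearest comparison is the value of compound 1 in this assay.

The step from compound 1 is expected to be small, a 1.3-fold lower number from compound 1 to compound 4 (0.11 log units; within the scatter), probably not beyond the scatter. Compound 4 is estimated at 50 nM, range 20 nM to 150 nM.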

Compound 4, half-maximal inhibitory concentration: 51 nM
Compound 4: the middle estimate sits 1.0-fold (0.01 log units) below what was measured; the range from low to high includes it.
By their numbers in this assay, from the lowest: compound 3; then compounds 4, 2 and 1 (each within the scatter of the next).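

On a nitrogen on an aromatic ring, 4-(trifluoromethoxy)phenyl in place of 2,3-dihydro-1H-inden-5-yl gives a 1.3-fold lower number from compound 1 to compound 4 (0.10 log units; within the scatter) in this assay. This position thus accepts the loss of the five-membered non-aromatic ring and the entry of oxygen and fluorine with no reading beyond the scatter. Nothing available gives a reason for this result.

Still open, as far as these compounds go, is whether an amine or a carboxylic acid in place of the trifluoromethoxy group would leave the number within the scatter. Whether a plain methyl on this nitrogen would do so is open as well.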